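The source may report more compounds than this note shows. Statements on the series, on what has been measured and on what is new or still open speak of the compounds shown alone.

Measured compounds in an assay on isolated protein for binding affinity to 5-hydroxytryptamine receptor 6 (Homo sapiens); on this read-out higher numbers stand for weaker inhibition and lower numbers for stronger inhibition:
compound 1 `COc1ccc(S(=O)(=O)Nc2cccc(I)c2)cc1N1CCNCC1` gives 0.501 nM
compound 2 `COc1ccc(S(=O)(=O)Nc2ccc(Cl)c(Cl)c2)cc1N1CCNCC1` gives 2.51 nM
compound 3 `COc1ccc(S(=O)(=O)Nc2c(F)cc(Br)cc2F)cc1N1CCNCC1` gives 158 nM

Compound 3 stands highest of the three numbers in this assay; the nearest is compound 2, separated by a 63-fold higher number from compound 2 to compound 3 (1.80 log units; beyond the scatter), and the furthest is compound 1, separated by a 320-fold higher number from compound 1 to compound 3 (2.50 log units; beyond the scatter). The step from compound 1 to compound 2 is the smaller one, a 5.0-fold higher number from compound 1 to compound 2 (0.70 log units; beyond the scatter).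

Compound 4 `COc1ccc(S(=O)(=O)Nc2cc(F)cc(F)c2Cl)cc1N1CCNCC1` is the next step from compound 3: 2-chloro-3,5-difluorophenyl in place of 4-bromo-2,6-difluorophenyl on a sulfonamide nitrogen. Within the data shown here, no measured pair covers this exact change. What bears on it is that the 4-bromo-2,6-difluorophenyl of compound 3 gives the weakest result in the set, while the 3-iodophenyl of compound 1 and the 3,4-dichlorophenyl of compound 2 sit far lower. Compound 4 carries a different halogen pattern again, so a move back toward the lower numbers is expected, but the size is uncertain and the direction rests only on compound 3 being the outlier. The step is estimated as a 5.3-fold lower number from compound 3 to compound 4 (0.72 log units; beyond the scatter), and compound 4 is expected to give 30 nM, between 5 nM and 200 nM.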

Compound 4, inhibition constant: 31.6 nM
Estimate against measurement, compound 4: 1.1-fold (0.02 log units) below; the measured number falls inside the stated range.
By their numbers in this assay, from the lowest: compound 1; then compound 2; then compound 4; then compound 3.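

In this assay, 2-chloro-3,5-difluorophenyl in place of 4-bromo-2,6-difluorophenyl on a sulfonamide nitrogen gives a 5.0-fold lower number from compound 3 to compound 4 (0.70 log units; beyond the scatter) beyond what compound 3 alone could show, so the read-out here responds to a change of halogen pattern even though the heavy-atom count of the group stays the same. The recovery is only partial, with a 13-fold higher number from compound 2 to compound 4 (1.10 log units; beyond the scatter) and a 63-fold higher number from compound 1 to compound 4 (1.80 log units; beyond the scatter) still separating this group from the 3,4-dichlorophenyl and the 3-iodophenyl. Nothing available here accounts for these steps.

Because every group shown carries only halogens, the compounds leave open how this place responds to a phenyl bearing a methoxy, a nitrile or an amine. Also open, as far as these compounds go, is how the unsubstituted phenyl or a 2-chlorophenyl without fluorine would compare, so the contribution of each halogen to these steps cannot yet be separated.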